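Dienone series: ring swap at the chain end

This account rests on a few compounds, and the source may have more. Where it says the series, first, only, none or still open, it means among the compounds named here.

Measured compounds:
compound 1, `COc1cc(/C=C/C(=O)/C=C/c2ccccc2)ccc1OCc1cn(CCCOc2cc(=O)oc3ccccc23)nn1`: 43%
compound 2, `COc1cc(/C=C/C(=O)/C=C/c2cccc3ccccc23)ccc1OCc1cn(CCCCOc2cc(=O)oc3ccccc23)nn1`: 50%
compound 3, `COc1ccc(/C=C/C(=O)/C=C/c2ccc(OCc3cn(CCOc4cc(=O)oc5ccccc45)nn3)c(OC)c2)cc1`: 68%

In a functional assay on COLO 205 cells (Homo sapiens) for inhibition, read by sulforhodamine B assay, with a stated time of 48 h, tested at 50 uM (on this read-out lower numbers stand for less inhibition of growth and higher numbers for more inhibition of growth at the one concentration tested), compound 1 gives the lowest of the three numbers. Compound 2 sits within the usual scatter of compound 1, so no order can be read between the two. Compound 3 lies beyond the scatter above compound 1; as the two differ in more than one place, the gap is noted only as what the two values show.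

Compound 4, `COc1cc(/C=C/C(=O)/C=C/c2ccco2)ccc1OCc1cn(CCCOc2cc(=O)oc3ccccc23)nn1`, has not been measured. It differs from compound 1 in one place: furan-2-yl in place of phenyl on a double-bonded chain carbon bound to a double-bonded chain carbon. The ring that leaves is phenyl, the ring that enters is furan-2-yl; the rest of the shared core is unchanged.

Within the data shown here, no measured pair in this set isolates such a ring swap, so nothing here sets its size. The expectation is a step from compound 1 to compound 4 of a number 2 percentage points higher from compound 1 to compound 4 (within the scatter), that is, none beyond the scatter in this assay. Compound 4 is therefore estimated at 45%, with a range of 30% to 60%.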

Compound 4, percent growth inhibition at one concentration: 59%
Beside the measured number, compound 4's estimate is 14 percentage points below it; measured number inside the range.
By their numbers in this assay, from the lowest: compounds 1, 2, 4 and 3 (each within the scatter of the next, the first and the last beyond it).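

In this assay, among these compounds, the swap to furan-2-yl in place of phenyl on a double-bonded chain carbon bound to a double-bonded chain carbon gives a number 16 percentage points higher from compound 1 to compound 4 (beyond the scatter) and is the only single-place step, showing that the ring at this position can move the number beyond the scatter. The change is modest, and it combines two differences: a smaller ring and a ring with one hydrogen-bond acceptor where phenyl has none. Nothing at hand separates these differences or gives a reason for the step.

From the compounds shown here alone, it remains open whether thiophen-2-yl or pyridin-2-yl at this position would read like furan-2-yl or like phenyl. Going by these compounds, it is also open whether the same swap gives a similar step on the cores of compound 2 and compound 3.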